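Trimming a Hydroxypropynyl Arm from a Bis-thioether Quinoline Analog

The compounds below may be only part of what the source reports. "The series", "measured", "known", "first", "only" and "open" are said of these compounds alone.

Of the compounds shown here, two have been tested in a functional assay on T47D cells (Homo sapiens) for antiproliferative activity, with a stated time of 72 h; a lower number here means a stronger inhibitor, a higher number a weaker inhibitor. Compound 1, with the structure `ClCC#CCSc1cnc2ccccc2c1Cl`, gives 3.2 ug/mL. Compound 2, with the structure `OCC#CCSc1cnc2ccccc2c1SCC#CCCl`, gives 5.3 ug/mL. Compound 2 has the higher of the two numbers, but its gap to compound 1 lies within the usual scatter of repeated measurements, so the two results cannot be told apart with confidence; no ordering between them is claimed here.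

The next compound, compound 3, with the structure `CSc1cnc2ccccc2c1SCC#CCCl`, has not yet been measured. It differs from compound 2 in a single place: hydrogen in place of 3-hydroxyprop-1-yn-1-yl on a saturated chain carbon bound to a sulfur. Cutting the change one bond further out, the 4-hydroxybut-2-yn-1-yl side arm becomes a plain methyl, while the other chain on the shared core remains unchanged.

Going by the values given here, with only two results in hand and no step between them beyond the scatter, there is little to anchor a prediction. Compound 3 is expected to behave much like compound 2, with a step of a 1.1-fold lower number from compound 2 to compound 3 (0.03 log units; within the scatter) in this assay, a change not expected to exceed the scatter. Compound 3 is therefore estimated at 5 ug/mL, with a plausible range from 2 ug/mL to 12 ug/mL.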

Compound 3, concentration for 50% inhibition: 3.9 ug/mL
For compound 3 the middle estimate is 1.3-fold (0.11 log units) above the measured one; low and high end bracket the measured number.
By their numbers in this assay, from the lowest: compounds 1, 3 and 2 (each within the scatter of the next).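

In this assay, going by these compounds alone, a step of a 1.4-fold lower number from compound 2 to compound 3 (0.13 log units; within the scatter) comes with hydrogen in place of 3-hydroxyprop-1-yn-1-yl on a saturated chain carbon bound to a sulfur, the first comparison here between two compounds that differ in one place. At this position, then, the 4-hydroxybut-2-yn-1-yl side arm, with its triple bond and its hydroxyl, can be swapped for a plain methyl with no difference that this read-out can separate from ordinary repeat-to-repeat variation, so the full arm is not required for antiproliferative activity in the range seen here. No separate measurement on these compounds helps to explain why the two results sit so close together.

Going by these compounds, whether any group at this sulfur could move the number beyond the scatter remains open, for example a longer chain ending in an amine or a carboxylic acid, since only the methyl and the 4-hydroxybut-2-yn-1-yl arm can be compared here. The other chain on the shared core is the same in compound 2 and compound 3, so this pair says nothing about what that chain contributes.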